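Series notes: aryl-alkynyl phenoxyacetic acids, fluoro for methoxymethyl

The compounds below may be only part of what the source reports. "The series", "measured", "known", "first", "only" and "open" are said of these compounds alone.

Measured so far in an assay on CHO cells for displacement of a labelled ligand from prostaglandin D2 receptor 2 (Homo sapiens), read by scintillation counting; a higher number here means a weaker inhibitor, a lower number a stronger inhibitor:
compound 1, `O=C(O)COc1ccc(Cl)cc1C#Cc1ccc(CO)cc1F`: 28 nM
compound 2, `CC(C)Cc1ccncc1C#Cc1cc(Cl)ccc1OCC(=O)O`: 4.9 nM
compound 3, `COCc1ccc(C#Cc2cc(Cl)ccc2OCC(=O)O)c(F)c1`: 22 nM

Compound 3 stands second highest of the three numbers in this assay. Among the measured compounds shown here, its nearest neighbour is compound 1, and the single one-place step recorded, a 1.3-fold lower number from compound 1 to compound 3 (0.10 log units; within the scatter), shows that methyl in place of hydrogen on an oxygen on a saturated carbon leaves the number essentially where it was. For the measured compounds named here, compound 2 gives a markedly lower number than compound 3; the two differ in more than one place, so no single step is drawn between them.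

The next compound, compound 4, `O=C(O)COc1ccc(Cl)cc1C#Cc1ccc(F)cc1F`, differs from compound 3 by fluoro in place of methoxymethyl on an aromatic carbon. Going by the values given here, no measured step covers the loss of the methoxymethyl group or the arrival of a fluoro at that position. Among the compounds with values here, the only step that bears on this site is the one from compound 1 to compound 3, which was within the scatter, suggesting the site tolerates a change of the group carried there without a large shift in the number. On that basis compound 4 is expected to show a step of about a 1.4-fold higher number from compound 3 to compound 4 (0.13 log units; within the scatter), not clearly beyond the scatter in either direction. The estimate for compound 4 in this assay is 30 nM, with a range from 10 nM to 90 nM.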

Compound 4, inhibition constant: 101 nM
For compound 4 the middle estimate is 3.4-fold (0.53 log units) below the measured one, and the stated range ends below it.
By their numbers in this assay, from the lowest: compound 2; then compounds 3 and 1 (each within the scatter of the next); then compound 4.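

In this assay, the aromatic carbon that carried the earlier change does not accept every replacement: fluoro in place of methoxymethyl gives a 4.6-fold higher number from compound 3 to compound 4 (0.66 log units; beyond the scatter), and fluoro in place of hydroxymethyl gives a 3.6-fold higher number from compound 1 to compound 4 (0.56 log units; beyond the scatter). Among the compounds shown here, the earlier step, a 1.3-fold lower number from compound 1 to compound 3 (0.10 log units; within the scatter), covered only an exchange on the oxygen of the group, whereas these two steps remove the whole chain, and both lie beyond the scatter, so among compound 1, compound 3 and compound 4 the two groups with an oxygen on a saturated carbon give the lower numbers and no compound here goes against this. No measurement is available that accounts for this shift.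

The three groups at this place do not separate the contribution of the oxygen from that of the saturated carbon, and a plain methyl, an ethyl or an aminomethyl group there would be needed to tell these apart. For the compounds shown here, whether the same replacement behaves alike on the core of compound 2 also remains open, as no step links that compound to the others.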